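This account rests on a few compounds, and the source may have more. Where it says the series, first, only, none or still open, it means among the compounds named here.

Compounds measured in a functional assay on NCI/ADR-RES cells (Homo sapiens) for inhibition; on this read-out higher numbers stand for weaker inhibition of growth and lower numbers for stronger inhibition of growth:
compound 1 `COc1cc(/C=C/C(=O)c2cccc(-n3cc(-c4ccc(Cl)cc4)[nH]c3=O)c2)cc(OC)c1OC`, 2360 nM
compound 2 `COc1cc(/C=C/C(=O)c2cccc(-n3cc(-c4ccccc4)[nH]c3=O)c2)ccc1O`, 2920 nM
compound 3 `COc1cc(/C=C/C(=O)c2cccc(-n3cc(-c4ccccc4)[nH]c3=O)c2)cc(OC)c1OC`, 1100 nM

Compound 3 gives the lowest of the three numbers in this assay: compound 1 stands a 2.1-fold lower number from compound 1 to compound 3 (0.33 log units; beyond the scatter), and compound 2 lies further off still. Compound 4 `COc1ccc(-c2cn(-c3cccc(C(=O)/C=C/c4cc(OC)c(OC)c(OC)c4)c3)c(=O)[nH]2)cc1` has not yet been measured; it differs from compound 3 by methoxy in place of hydrogen on an aromatic carbon. Going by the values given here, only one measured step touches the same position: a 2.1-fold lower number from compound 1 to compound 3 (0.33 log units; beyond the scatter), a modest change when chloro was exchanged for hydrogen there. Among the compounds with values here, no compound shows methoxy at this place, so the direction is uncertain, and a step of similar modest size is expected, perhaps toward a somewhat higher number. For compound 4 the expected value is 1600 nM, within 600 nM to 4500 nM, meaning an expected step of a 1.5-fold higher number from compound 3 to compound 4 (0.16 log units; within the scatter).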

Compound 4, concentration for 50% growth inhibition: 1700 nM
The estimate for compound 4 lay 1.1-fold (0.03 log units) below the measured number; low and high end bracket the measured number.
By their numbers in this assay, from the lowest: compounds 3, 4, 1 and 2 (each within the scatter of the next, the first and the last beyond it).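

Methoxy at this position gives a number in this assay that lies within the scatter of both hydrogen (a 1.5-fold higher number from compound 3 to compound 4 (0.19 log units; within the scatter)) and chloro (a 1.4-fold lower number from compound 1 to compound 4 (0.14 log units; within the scatter)). Compound 4 therefore cannot be separated from either compound, even though the hydrogen and chloro compounds are separated from each other (a 2.1-fold lower number from compound 1 to compound 3 (0.33 log units; beyond the scatter)). No measurement here accounts for these numbers.

Going by these compounds, whether an amine, a carboxylic acid or a longer chain at this place would move the number beyond the scatter stays open. So does whether methoxy here would give a similar step with the other end of the molecule found in compound 2.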